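From Fluoro to Chloro: Expecting Little Change

This account rests on a few compounds, and the source may have more. Where it says the series, first, only, none or still open, it means among the compounds named here.

In a functional assay on EBC-1 cells (Homo sapiens) for antiproliferative activity, with a stated time of 72 h (a lower number here means a stronger inhibitor, a higher number a weaker inhibitor), compound 1 `CNC(=O)c1cccc(-c2cc(F)c3ncc(Cc4ccc5ncccc5c4)n3c2)c1` gives 400 nM and compound 2 `CNC(=O)c1cc(-c2cc(F)c3ncc(Cc4ccc5ncccc5c4)n3c2)ccc1F` gives 246 nM. Going by the values given here, these two numbers lie within the scatter of each other, so compound 2 stands level with the only other compound measured so far. Compound 3 `CNC(=O)c1cc(-c2cc(F)c3ncc(Cc4ccc5ncccc5c4)n3c2)ccc1Cl` alters compound 2 in a single place: chloro in place of fluoro on an aromatic carbon. It has chloro in place of fluoro on an aromatic carbon, ortho to a methylcarbamoyl group and para to a large group. Among the compounds with values here, one measured step bears on this carbon: a 1.6-fold lower number from compound 1 to compound 2 (0.21 log units; within the scatter), where fluoro replaced hydrogen, and it stayed within the scatter. Within the data shown here, no chloro compound has been measured yet, so this single small step is the only guide, and no shift beyond the scatter is expected in this assay. The estimated step is a 1.1-fold lower number from compound 2 to compound 3 (0.05 log units; within the scatter). For compound 3 the expected value is 220 nM, with an estimated range of 100 nM to 500 nM.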

Compound 3, half-maximal inhibitory concentration: 946 nM
Estimate against measurement, compound 3: 4.3-fold (0.63 log units) below; the measured number lies above the stated range.
By their numbers in this assay, from the lowest: compounds 2 and 1 (each within the scatter of the next); then compound 3.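

This carbon, ortho to a methylcarbamoyl group and para to a large group, proved sensitive to which halogen it carries: in this assay there is a 3.8-fold higher number from compound 2 to compound 3 (0.58 log units; beyond the scatter) even though one heavy atom simply replaces another, with no ring, hydrogen-bond donor, hydrogen-bond acceptor or net charge gained or lost. Chloro also stands apart from hydrogen, with a 2.4-fold higher number from compound 1 to compound 3 (0.37 log units; beyond the scatter) on that comparison. Hydrogen and fluoro remain within the scatter of each other, so among these three compounds only chloro moves the number beyond the scatter, and it moves it upward.

Nothing available here explains why chloro differs from fluoro at this carbon. As far as these compounds go, it remains open whether a bromo, a methyl or a methoxy group on the same carbon would raise the number as chloro does or stay level with fluoro and hydrogen.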